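The compounds below may be only part of what the source reports. "The series", "measured", "known", "first", "only" and "open" are said of these compounds alone.

Measured compounds:

compound 1 `Cc1nc(N)c2c(-c3ccccc3)cn([C@@H]3O[C@H](CO)[C@@H](O)[C@H]3O)c2n1` — > 20000 nM, a limit of the assay.
compound 2 `Cc1nc(N)c2c(-c3cccs3)cn([C@@H]3O[C@H](CO)[C@@H](O)[C@H]3O)c2n1` — > 20000 nM, a limit of the assay.
compound 3 `COc1ncnc2c1c(-c1cccs1)cn2[C@@H]1O[C@H](CO)[C@@H](O)[C@H]1O` — 4850 nM.

Within the data shown here, in a functional assay on A549 cells (Homo sapiens), read by MTT assay, with a stated time of 72 h (on this read-out lower numbers stand for stronger inhibition and higher numbers for weaker inhibition), compound 3 gives 4850 nM, the only number in the set. Compound 2 reaches only the limit > 20000 nM in this assay. Compound 1 likewise reaches only the limit > 20000 nM in this assay. The change from compound 2 to compound 1 is phenyl in place of thiophen-2-yl on an aromatic carbon; its step that the two limits leave unreadable from compound 2 to compound 1 cannot be read, because the limit of > 20000 nM in this assay, at which 2 of the 3 values shown sit, holds both ends of the pair. How the core of compound 3 differs from the core of compound 2 is not broken down here.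

Compound 4 `COc1ncnc2c1c(-c1ccccc1)cn2[C@@H]1O[C@H](CO)[C@@H](O)[C@H]1O` is not yet measured. It differs from compound 3 by phenyl in place of thiophen-2-yl on an aromatic carbon, the same change, in the same place, as from compound 2 to compound 1; this change occurs in two pairs among the compounds shown. Among the measured compounds shown here, the only measured instance of it gives no readable size, so no direction can be taken from it. For compound 4 the step of a 1.2-fold higher number from compound 3 to compound 4 (0.09 log units; within the scatter) is expected to stay within the usual scatter of this assay, an assumption resting on the unreadable step that the two limits leave unreadable from compound 2 to compound 1 and on the value of compound 3 4850 nM as the only anchor. Compound 4 is therefore estimated at 6000 nM in this assay, with a range from 2500 nM to 15000 nM.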

Compound 4, half-maximal inhibitory concentration: > 20000 nM
Compound 4: only a limit was reported; the forecaster's own chance of this, stated with the estimate: 20%; middle value at least 3.3-fold (0.52 log units) from the limit.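

In this assay, phenyl in place of thiophen-2-yl on an aromatic carbon of the core of compound 3 gives an at least 4.1-fold higher number from compound 3 to compound 4 (0.61 log units; beyond the scatter), so on this core the change carries a cost that lies beyond the scatter, and the printed size is only the smallest the data allow. Compound 4 gives > 20000 nM, which is a limit of the assay and not a number. The same change on the core of compound 2 cannot be read, so the data do not show that the step carries over from one core to the other, nor that its size is shared, because both ends of that pair sit at the limit: the limit of > 20000 nM in this assay, at which 3 of the 4 values shown sit.

Among these compounds, compound 3 remains the only compound with a number, so no second core is available on which the size of this step could be compared. Also open, on these data alone, is whether a different group on the same aromatic carbon, such as an amine, a carboxylic acid or a longer chain, would give a readable number on the core of compound 3 or on the core of compound 2.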